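The source may hold more compounds than are shown below. What is called first, only, known or untested is meant among the compounds shown, and "the series" means these compounds.

Measured compounds:
compound 1, `CCCCCCCCn1cc(COC[C@@H]2OC[C@H](N)[C@@H]2O)nn1`, 70400 nM
compound 2, `CCCCCCCCCCn1cc(COC[C@@H]2OC[C@H](N)[C@@H]2O)nn1`, 8780 nM

Both compounds share one core and differ only in the length of the saturated chain attached to the aromatic nitrogen. In a functional assay on MGC-803 cells (Homo sapiens) for antiproliferative activity, read by MTT assay, with a stated time of 48 h (on this read-out higher numbers stand for weaker inhibition and lower numbers for stronger inhibition), compound 1 gives 70400 nM, while compound 2 gives 8780 nM. The step of an 8.0-fold lower number from compound 1 to compound 2 (0.90 log units; beyond the scatter) is beyond the scatter, so compound 2 stands as the lower of the two numbers shown, with compound 1 as its only neighbour.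

Compound 3, `CCCCCCCCCCCCn1cc(COC[C@@H]2OC[C@H](N)[C@@H]2O)nn1`, has not yet been measured. It differs from compound 2 by ethyl in place of hydrogen on a saturated chain carbon, ten or more bonds along the chain from an aromatic nitrogen. Among the compounds with values here, the one measured step that bears on this change is an 8.0-fold lower number from compound 1 to compound 2 (0.90 log units; beyond the scatter), where the same exchange of ethyl for hydrogen, made closer to the aromatic nitrogen, lowered the number clearly. Two compounds cannot show whether a second lengthening of the chain keeps that trend going or levels off. The expectation is therefore a further lowering in this assay, probably smaller than an 8.0-fold lower number from compound 1 to compound 2 (0.90 log units; beyond the scatter). For compound 3 the expected value in this assay is 3500 nM, within a range from 1000 nM to 12000 nM, which would mean an expected step of a 2.5-fold lower number from compound 2 to compound 3 (0.40 log units; beyond the scatter).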

Compound 3, half-maximal inhibitory concentration: 21400 nM
Compound 3: the middle estimate sits 6.1-fold (0.79 log units) below what was measured; measured number above the stated range.
By their numbers in this assay, from the lowest: compound 2; then compound 3; then compound 1.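

In this assay, the exchange of ethyl for hydrogen on a saturated chain carbon, along the chain from an aromatic nitrogen, reverses the direction seen earlier: the step is a 2.4-fold higher number from compound 2 to compound 3 (0.39 log units; beyond the scatter), whereas the same exchange made closer to the aromatic nitrogen gave an 8.0-fold lower number from compound 1 to compound 2 (0.90 log units; beyond the scatter). Lengthening the chain therefore does not lower the number steadily across these three compounds, and compound 3 goes against any such trend, although the longest chain still retains part of the improvement, with a 3.3-fold lower number from compound 1 to compound 3 (0.52 log units; beyond the scatter). No measurement available here explains why the direction changes at this position.

Three chain lengths cannot show whether a still longer chain would raise the number further, or whether a chain of intermediate length would give a lower number than compound 2. As far as these compounds go, it also remains open whether a chain carrying an amine or a carboxylic acid would follow the same course as these plain saturated chains.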